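A Second Methyl on the Outer Ring

This account rests on a few compounds, and the source may have more. Where it says the series, first, only, none or still open, it means among the compounds named here.

In an in vitro functional assay on 1321-N1 cells for agonist activity at Free fatty acid receptor 1 (Homo sapiens), read by fluorescence (a higher number here means that more compound is needed for the effect, a lower number that less compound is needed), compound 3 `Cc1cccc(C#Cc2ccc(CCC(=O)O)cc2)c1` gives 43.7 nM, the lowest of the three numbers in hand, although the other two sit within the scatter of it: compound 1 `O=C(O)CCc1ccc(C#Cc2cccc([N+](=O)[O-])c2)cc1` gives 58.9 nM and compound 2 `Cc1cccc(C#Cc2ccc(CCC(=O)O)cc2)c1C` gives 87.1 nM. Both steps, a 1.3-fold lower number from compound 1 to compound 3 (0.13 log units; within the scatter) and a 2.0-fold lower number from compound 2 to compound 3 (0.30 log units; within the scatter), stay within the scatter, so exchanging small groups on this ring has so far barely moved the numbers. Compound 4 `Cc1cc(C)cc(C#Cc2ccc(CCC(=O)O)cc2)c1` differs from compound 3 by methyl in place of hydrogen on an aromatic carbon. Within the data shown here, the only step that speaks to an extra methyl on this ring, a 2.0-fold lower number from compound 2 to compound 3 (0.30 log units; within the scatter), was within the scatter, so no change beyond the scatter is expected here, and the step of a 1.0-fold higher number from compound 3 to compound 4 (0.01 log units; within the scatter) is the estimate. Compound 4 is expected to give about 45 nM, between 20 nM and 100 nM.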

Compound 4, half-maximal effective concentration: 74.1 nM
For compound 4 the middle estimate is 1.6-fold (0.22 log units) below the measured one; measured number inside the range.
By their numbers in this assay, from the lowest: compounds 3, 1, 4 and 2 (each within the scatter of the next).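

In this assay, adding a methyl on an aromatic carbon, meta to a large group and meta to a methyl group, gives a 1.7-fold higher number from compound 3 to compound 4 (0.23 log units; within the scatter). This carbon therefore takes a methyl with no change beyond the scatter, a reading that compound 2, with its extra methyl on another carbon, could not give. From the compounds shown here alone, whether an amine or a methoxy group on this same carbon would also stay within the scatter of compound 3 remains open. No measurement shown here explains this result.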